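Trading a Nitrile for a Methyl on a Bridged Core

The source may report more compounds than this note shows. Statements on the series, on what has been measured and on what is new or still open speak of the compounds shown alone.

Measured so far:
compound 1, `N#Cc1ccc2c(c1)C1CNCC2C1`: 0.5 nM
compound 2, `Oc1cccc2c1C1CNCC2C1`: 1700 nM

Both numbers come from an assay on HEK293 cells for binding affinity to Neuronal acetylcholine receptor; alpha4/beta2 (Homo sapiens); a higher number here means a weaker inhibitor, a lower number a stronger inhibitor. Of the two, compound 1 holds the lower number, and its gap to compound 2 is far beyond the usual scatter, so compound 1 is clearly the stronger binder of the pair. The two compounds differ in more than one place, so only what the values show can be said: the nitrile-bearing compound 1 binds very tightly, while the hydroxyl-bearing compound 2 binds weakly.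

Compound 3, `Cc1ccc2c(c1)C1CNCC2C1`, has not yet been measured. It differs from compound 1 in a single place: methyl in place of cyano on an aromatic carbon. For the measured compounds named here, no step between measured compounds isolates this change, so the size of the effect is uncertain. Compound 3 is expected to bind less tightly than compound 1, with an estimated step of a 40-fold higher number from compound 1 to compound 3 (1.60 log units; beyond the scatter) in this assay, toward a higher number. For compound 3 a value near 20 nM is expected, within a range from 3 nM to 150 nM.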

Compound 3, inhibition constant: 1.6 nM
Compound 3: middle estimate off by 13-fold (1.10 log units), on the high side, and the stated range ends above it.
By their numbers in this assay, from the lowest: compound 1; then compound 3; then compound 2.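

Replacing cyano with methyl on this aromatic carbon, which is meta to one fused ring and para to another, gives a 3.2-fold higher number from compound 1 to compound 3 (0.51 log units; beyond the scatter) in this assay. The step is beyond the scatter but modest, so the nitrile contributes to the tight binding of compound 1 without being essential to it: compound 3, with a smaller group that counts no hydrogen-bond acceptor and has no triple bond, still gives 1.6 nM. No accompanying measurement explains why the two groups differ by this amount, so the result describes the size of the change and not its cause.

Going by these compounds, with only cyano and methyl compared at this position, it remains open how wider changes would behave, such as an amine, a carboxylic acid, a longer chain such as propyl, or a plain hydrogen in place of either group. Compound 2 differs from both of the others in more than one place. Its much weaker binding cannot yet be tied to any single structural change.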